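Swapping Cyclohexyl for Pyridin-3-yl on a Ring Amine

The source may report more compounds than this note shows. Statements on the series, on what has been measured and on what is new or still open speak of the compounds shown alone.

Of the compounds shown here, three built on one shared core have been measured in a functional assay on HeLa cells (Homo sapiens) for antiproliferative activity, read by CCK-8 assay, with a stated time of 72 h, tested at 2 uM; a lower number here means a weaker effect, a higher number a stronger effect of the compound at the concentration tested. Compound 1 `Nc1ccccc1NC(=O)c1ccc(CSC(=S)N2CCN(C3CCCCC3)CC2)cc1` gives 30.6%, the second highest of the three numbers. Compound 2 `Nc1ccccc1NC(=O)c1ccc(CSC(=S)N2CCc3cc([N+](=O)[O-])ccc32)cc1` gives 32.6%, which sits within the scatter of the number for compound 1. Among the measured compounds shown here, compound 3 `CN(Cc1cccnc1)C(=S)SCc1ccc(C(=O)Nc2ccccc2N)cc1` gives 16.4%, a number that lies beyond the scatter below the one for compound 1.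

Compound 4 `Nc1ccccc1NC(=O)c1ccc(CSC(=S)N2CCN(c3cccnc3)CC2)cc1` is drawn from compound 1 by one change: pyridin-3-yl in place of cyclohexyl on an amine nitrogen in a ring. For the measured compounds named here, no pair of measured compounds isolates this change. Going by the values given here, compound 3 also carries a pyridin-3-yl group, but on a different amine and together with other differences, so its two values with compound 1 show only that a pyridine-bearing compound in this set scored lower. Some drop is therefore expected, though it may stay within the scatter. Compound 4 is expected to give 24% in this assay, with a range from 10% to 38%. The expected step is a number 6.6 percentage points lower from compound 1 to compound 4 (within the scatter).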

Compound 4, a percentage reported as inhibition, at one concentration (the size of the read-out at that concentration, not a potency): 66.2%
The estimate for compound 4 lay 42.2 percentage points below the measured number; measured number outside the range, above it.
By their numbers in this assay, from the lowest: compound 3; then compounds 1 and 2 (each within the scatter of the next); then compound 4.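

In this assay, among the compounds shown here, the amine nitrogen in the ring proves sensitive to the group it carries: pyridin-3-yl in place of cyclohexyl gives a number 35.6 percentage points higher from compound 1 to compound 4 (beyond the scatter) and is the only step here that isolates one change. The two groups match in heavy-atom count and are both six-membered rings, so the step accompanies the exchange of a non-aromatic carbon ring for an aromatic ring with one nitrogen and one hydrogen-bond acceptor. No evidence at hand bears on what lies behind this rise.

A phenyl group at the same place would separate the contribution of the aromatic ring from that of its nitrogen, and pyridin-4-yl would test whether the place of that nitrogen matters. The read-out also comes from one concentration, so it leaves the potency of compound 4 open.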